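A few compounds are considered here, and "the series" means these few. Any claim that something is new, unique, unknown or untested is made for them only; others in the source may bear on it.

Compound 1 `Clc1ccc2nc(-c3cccnc3)n(C3CC3)c2c1` is one of two compounds for which a number is available. In an assay on V79 cells for inhibition of cytochrome P450 11B1, mitochondrial (Homo sapiens), read by HTRF, with a stated time of 1 h (on this read-out lower numbers stand for stronger inhibition and higher numbers for weaker inhibition), compound 1 gives 477 nM. Its companion, compound 2 `Cn1c(-c2cccnc2)nc2ccc(F)cc21`, gives 677 nM in this assay, and the two numbers lie within the usual scatter of each other, so neither compound can be set above the other on this evidence.

The next compound, compound 3 `COc1ccc2nc(-c3cccnc3)n(C3CC3)c2c1`, departs from compound 1 at a single place: methoxy in place of chloro on an aromatic carbon. Among the compounds with values here, no pair among the measured compounds shows this exchange, so there is no measured step to lean on, and the expectation rests on the size of the change alone, a small group replaced by a small group on the shared core of compound 1.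

The step from compound 1 to compound 3 in this assay is expected to be modest, if anything toward a slightly higher number, and may well stay within the scatter: a 1.5-fold higher number from compound 1 to compound 3 (0.17 log units; within the scatter). Compound 3 is therefore estimated at 700 nM in this assay, with a range from 300 nM to 1600 nM.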

Compound 3, half-maximal inhibitory concentration: 1980 nM
For compound 3 the middle estimate is 2.8-fold (0.45 log units) below the measured one; measured number outside the range, above it.
By their numbers in this assay, from the lowest: compounds 1 and 2 (each within the scatter of the next); then compound 3.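

In this assay, within the data shown here, the exchange on this aromatic carbon, meta to a fused ring and para to a fused ring, gives a 4.2-fold higher number from compound 1 to compound 3 (0.62 log units; beyond the scatter) on the shared core, the first change in one place for which a size can be read. It shows that this position does not treat chloro and methoxy alike: replacing one heavy atom, a chlorine, with two, a carbon and an oxygen, one of which counts as a hydrogen-bond acceptor, moves the number beyond the scatter toward weaker inhibition. Nothing measured here accounts for this shift.

What the compounds leave open is which feature of methoxy goes with the higher number, its oxygen or its greater count of heavy atoms; a hydroxy, an ethyl or a nitrile on the same carbon of the core of compound 1 would begin to separate these readings. On these data alone, it is also open whether the position has any room for a gain over chloro, a question that a trifluoromethyl or an amine at this place could address.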